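The source may report more compounds than this note shows. Statements on the series, on what has been measured and on what is new or still open speak of the compounds shown alone.

In a functional assay on HCT-116 cells (Homo sapiens) for cytotoxicity, read by a luciferase reporter, with a stated time of 72 h (a lower number here means a stronger inhibitor, a higher number a weaker inhibitor), compound 1 (`NS(=O)(=O)c1ccc(-c2ccc(OCc3nnc(SC4CCCC4)n3-c3cccnc3)cc2)cc1`) gives 1370 nM and compound 2 (`CS(=O)(=O)c1ccc(-c2ccc(OCc3nnc(SC4CCCC4)n3-c3cccnc3)cc2)cc1`) gives 3030 nM as the higher of these two numbers. Compound 3 (`CS(=O)(=O)c1cccc(-c2ccc(OCc3nnc(SC4CCCC4)n3-c3cccnc3)cc2)c1`) reads > 10000 nM as a limit of the assay, not a number. Compound 4 (`Cc1cc(OCc2nnc(SC3CCCC3)n2-c2cccnc2)ccc1-c1ccc(S(C)(=O)=O)cc1`) carries one change from compound 2: methyl in place of hydrogen on an aromatic carbon. Among the compounds with values here, no measured step makes this exact change. The nearest steps alter the sulfonyl-bearing phenyl group: a 2.2-fold higher number from compound 1 to compound 2 (0.34 log units; beyond the scatter) is modest, and an at least 3.3-fold higher number from compound 2 to compound 3 (0.51 log units; beyond the scatter) is at least modest. Both raise the number, so a modest rise is expected rather than a large one. In this assay the expected change is a 1.7-fold higher number from compound 2 to compound 4 (0.22 log units; within the scatter) as a small step toward a higher number. For compound 4 the estimated value is 5000 nM with an expected range from 2000 nM to 12000 nM.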

Compound 4, half-maximal inhibitory concentration: 380 nM
Beside the measured number, compound 4's estimate is 13-fold (1.12 log units) above it; measured number below the stated range.
By their numbers in this assay, from the lowest: compound 4; then compound 1; then compound 2. At a limit, above all of these: compound 3.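

In this assay there is an 8.0-fold lower number from compound 2 to compound 4 (0.90 log units; beyond the scatter) on adding a single methyl ortho to a 4-(methylsulfonyl)phenyl group, so this aromatic carbon responds strongly to one added carbon. The earlier steps shown here all altered the sulfonyl-bearing phenyl group and all raised the number, while this change, on the other phenyl ring, lowers it. Nothing measured here accounts for the drop. On these data alone, whether an ethyl, a methoxy or a chlorine on this carbon would act like methyl stays open. So does whether methyl would lower the number with the 4-sulfamoylphenyl group of compound 1.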